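Adding a Methyl to Compound 3: An Estimate

The source may report more compounds than this note shows. Statements on the series, on what has been measured and on what is new or still open speak of the compounds shown alone.

Compounds measured so far:
- compound 1 `Nc1nc(-c2ccc(C3CC3)o2)nc2sc(Cc3ccccc3)cc12` gives 861 nM
- compound 2 `Cc1csc(-c2nc(N)c3cc(Cc4ccccc4)sc3n2)n1` gives 1490 nM
- compound 3 `N#Cc1cccc(-c2nc(N)c3cc(Cc4ccccc4)sc3n2)c1` gives 222 nM

All three numbers come from a functional assay on CHO-K1 cells for antagonist activity at adenosine receptor A1 (Homo sapiens), read by a beta-galactosidase reporter and cAMP accumulation, with stated times of 15 min and 6 h; a higher number here means a weaker inhibitor, a lower number a stronger inhibitor. The three compounds share one core and differ only in the aromatic group attached to it. Compound 3 has the lowest number of the three: the step of a 3.9-fold lower number from compound 1 to compound 3 (0.59 log units; beyond the scatter) and the step of a 6.7-fold lower number from compound 2 to compound 3 (0.83 log units; beyond the scatter) both go beyond the scatter, while the step of a 1.7-fold higher number from compound 1 to compound 2 (0.24 log units; within the scatter) does not.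

Compound 4 `CC(c1ccccc1)c1cc2c(N)nc(-c3cccc(C#N)c3)nc2s1` has not yet been measured. It keeps the 3-cyanophenyl group of compound 3 and alters a different part of the molecule: methyl in place of hydrogen on a saturated chain carbon bound to two aromatic carbons. Going by the values given here, none of the measured steps touches this carbon; each of them swaps the aromatic group on the core, so the data give no direct guide to a methyl entering here. Compound 4 is therefore expected to show a step of a 1.2-fold higher number from compound 3 to compound 4 (0.07 log units; within the scatter) that stays within the scatter, and the range around it is kept wide to reflect the lack of a comparable step. The estimate for compound 4 in this assay is 260 nM, expected to fall between 80 nM and 850 nM.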

Compound 4, inhibition constant: 1770 nM
For compound 4 the middle estimate is 6.8-fold (0.83 log units) below the measured one; the whole stated range lies below it.
By their numbers in this assay, from the lowest: compound 3; then compounds 1, 2 and 4 (each within the scatter of the next, the first and the last beyond it).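

The earlier compounds shown here differed only in the aromatic group on the shared core, so they said nothing about the saturated chain carbon bound to two aromatic carbons. Going from benzyl to 1-phenylethyl in this assay gives an 8.0-fold higher number from compound 3 to compound 4 (0.90 log units; beyond the scatter) and shows that this carbon responds to even a small change: the entering methyl is a single heavy atom, yet the result is a weaker inhibitor. That step is similar in size to the largest swap of the aromatic group, a 6.7-fold lower number from compound 2 to compound 3 (0.83 log units; beyond the scatter), so this carbon matters to the number about as much as the choice of aromatic group does, and no evidence at hand says why.

The compounds shown leave open whether the drop belongs to methyl alone or extends to other groups on this carbon, such as an ethyl, a hydroxyl or a fluorine atom. They also leave open whether the methyl has a similar effect when the 3-cyanophenyl is replaced by 5-cyclopropylfuran-2-yl or 4-methyl-1,3-thiazol-2-yl.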